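A few compounds are considered here, and "the series" means these few. Any claim that something is new, unique, unknown or untested is made for them only; others in the source may bear on it.

The shared core appears in compound 1 `O=C(/C(=N/O)Nc1ccc(F)c(Br)c1)C1CCN(C(=O)NCc2ccccc2)CC1`, compound 2 `O=C(/C(=N/O)Nc1ccc(F)c(Br)c1)[C@H]1CC[C@H](NS(=O)(=O)Nc2ccccc2)CC1` and compound 3 `Cn1cc(-c2ccc(NC(=O)N3CCC(C(=O)/C(=N/O)Nc4ccc(F)c(Br)c4)CC3)cc2)cn1`. Within the data shown here, in an assay for inhibition of Tryptophan 2,3-dioxygenase (Homo sapiens), with a stated time of 1 h (on this read-out lower numbers stand for stronger inhibition and higher numbers for weaker inhibition), compound 1 gives 89800 nM, the only actual number among the three. For compound 2, this assay reports only a limit, > 100000 nM. For compound 3, this assay likewise reports only a limit, > 100000 nM. The weak end of this set is marked by the limit of > 100000 nM in this assay, at which 2 of the 3 values shown sit. Compound 4 `O=C(/C(=N/O)Nc1ccc(F)c(Br)c1)C1CCN(c2ccccc2)CC1` has not yet been measured; it differs from compound 1 by phenyl in place of benzylcarbamoyl on an amine nitrogen in a ring. Among the measured compounds shown here, no step between two measured compounds is available, so the size of this change in this assay cannot be read from the data; a shift no larger than the usual scatter, in either direction, is expected. Compound 4 is therefore estimated at 80000 nM, between 25000 nM and 150000 nM, an expected step of a 1.1-fold lower number from compound 1 to compound 4 (0.05 log units; within the scatter).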

Compound 4, half-maximal inhibitory concentration: > 100000 nM
Compound 4 gave a limit, no number (the forecaster's own chance of this, stated with the estimate: 40%); middle value at least 1.2-fold (0.09 log units) from the limit.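

In this assay, among these compounds, phenyl in place of benzylcarbamoyl on the amine nitrogen in the ring gives the first step in this set: an at least 1.1-fold higher number from compound 1 to compound 4 (0.04 log units; that floor lies within the scatter). Compound 4 carries a limit and not a number, so this step is only a floor and the true size of the change cannot be read. The only actual number in the set remains that of compound 1, and the read-out separates the other compounds no further: the limit of > 100000 nM in this assay, at which 3 of the 4 values shown sit.

On these data alone, whether an acetyl group or a carboxylic acid on this nitrogen would give a clearly lower number stays open.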